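Triazole Chain End Swap: Carboxy Replaced by Hydroxy

The source may report more compounds than this note shows. Statements on the series, on what has been measured and on what is new or still open speak of the compounds shown alone.

Compound 3 `O=C(O)CCc1cn(-c2ccc(NC(=O)Nc3ccccc3C(F)(F)F)cc2)nn1` has no number in an assay on isolated protein for inhibition of ATP-dependent RNA helicase DDX3X (Homo sapiens), read by FRET, with stated times of 30 s and 40 min; a lower number here means a stronger inhibitor, a higher number a weaker inhibitor; in this assay compound 3 gives "not determined" (no result reported), so its standing among the measured compounds cannot be given. Compound 4 `O=C(Nc1ccc(-n2cc(CCO)nn2)cc1)Nc1ccccc1C(F)(F)F` differs from it by hydroxy in place of carboxy on a saturated chain carbon, two bonds along the chain from an aromatic carbon. Among the compounds with values here, the only measured step at the same place is the one in which compound 1 `COCCc1cn(-c2ccc(NC(=O)Nc3ccccc3C)cc2)nn1` becomes compound 2 `Cc1ccccc1NC(=O)Nc1ccc(-n2cc(CCCN(C)C)nn2)cc1`: in this assay compound 1 gives 1000 nM and compound 2 gives 2900 nM, a change of a 2.9-fold higher number from compound 1 to compound 2 (0.46 log units; beyond the scatter). That step shows the chain end does move the number, though modestly, and compound 1 with its methoxyethyl chain is the closest measured relative of compound 4. Compound 4 is therefore expected to fall near compound 1, with an estimated value of 1500 nM and a range from 500 nM to 5000 nM.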

Compound 4, half-maximal inhibitory concentration: 11200 nM
Beside the measured number, compound 4's estimate is 7.5-fold (0.87 log units) below it; the whole stated range lies below it.
By their numbers in this assay, from the lowest: compound 1; then compound 2; then compound 4.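

In this assay, within the data shown here, compound 3 has no number, so no step to compound 4 can be read. The compounds shown leave open what hydroxy in place of carboxy does to the number. Nothing given here bears on the result for compound 4.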